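Chloro for Methyl on the Shared Core of Compound 1

This account rests on a few compounds, and the source may have more. Where it says the series, first, only, none or still open, it means among the compounds named here.

Compound 1 `CNc1cc(Oc2c(C)cc(NC(=O)Nc3cccc(C(F)(F)F)c3)cc2C)ncn1` carries the lowest number of the three measured. In an assay on isolated protein for inhibition of serine/threonine-protein kinase TNNI3K (Homo sapiens) (on this read-out higher numbers stand for weaker inhibition and lower numbers for stronger inhibition), compound 1 gives 25 nM. Compound 2 `CC(C)CNc1cc(Oc2ccc(NC(=O)Nc3cccc(C(F)(F)F)c3)cc2)ncn1` gives 50 nM in this assay, a gap within the scatter. Among the measured compounds shown here, compound 3 `CN(C)c1cc(Oc2ccc(NC(=O)Nc3cccc(C(F)(F)F)c3)cc2)ncn1` gives 2500 nM in this assay, and the step of a 50-fold higher number from compound 2 to compound 3 (1.70 log units; beyond the scatter) is the only measured step in the set. Compound 4 `CNc1cc(Oc2c(C)cc(NC(=O)Nc3cccc(C(F)(F)F)c3)cc2Cl)ncn1` differs from compound 1 at one place: chloro in place of methyl on an aromatic carbon. For the measured compounds named here, the measured step concerns the amine on the shared core, not the aromatic carbon changed here, so no measured step bears on this change. The number for compound 4 is therefore expected to stay within the scatter, a 1.2-fold higher number from compound 1 to compound 4 (0.08 log units; within the scatter). Compound 4 is estimated at 30 nM in this assay, between 10 nM and 90 nM.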

Compound 4, half-maximal inhibitory concentration: 79 nM
Compound 4: the middle estimate sits 2.6-fold (0.42 log units) below what was measured; measured number inside the range.
By their numbers in this assay, from the lowest: compounds 1, 2 and 4 (each within the scatter of the next, the first and the last beyond it); then compound 3.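

On the shared core, the aromatic carbon ortho to the (6-(methylamino)pyrimidin-4-yl)oxy group proves sensitive to its substituent: chloro in place of methyl gives a 3.2-fold higher number from compound 1 to compound 4 (0.50 log units; beyond the scatter) in this assay and so moves the number beyond the scatter. Among the compounds shown here, this is the first step seen at this carbon, as the earlier step concerned only the amine. Nothing given here accounts for the step. From the compounds shown here alone, whether fluoro, bromo or methoxy at this carbon would stay nearer to methyl or to chloro remains open. So does whether the step would hold with a different amine on the core.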